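A few compounds are considered here, and "the series" means these few. Any claim that something is new, unique, unknown or untested is made for them only; others in the source may bear on it.

In a functional assay on MGC-803 cells (Homo sapiens) for inhibition, read by MTT assay, with a stated time of 72 h (a lower number here means a stronger inhibitor, a higher number a weaker inhibitor), compound 3 `Cc1cc(Nc2cc(-c3ccccc3)[nH]n2)n2nc(SCc3nc4ccccc4[nH]3)nc2n1` gives 1790 nM, the lowest of the three numbers, ahead of compound 1 `Cc1cc(Nc2cc(-c3ccccc3)[nH]n2)n2nc(SCc3c(Cl)cccc3Cl)nc2n1` at 5280 nM and compound 2 `C#CCSc1nc2nc(C)cc(Nc3cc(-c4ccccc4)[nH]n3)n2n1` at 13400 nM. Compound 4 `Cc1cc(Nc2cc(-c3ccccc3)[nH]n2)n2ncnc2n1` differs from compound 3 by hydrogen in place of ((1H-benzimidazol-2-yl)methyl)sulfanyl on an aromatic carbon, so the whole side chain on sulfur is gone. For the measured compounds named here, no measured compound lacks that chain, and the only guidance comes from exchanges within it: a 2.9-fold lower number from compound 1 to compound 3 (0.47 log units; beyond the scatter), a 2.5-fold higher number from compound 1 to compound 2 (0.40 log units; beyond the scatter) and a 7.5-fold lower number from compound 2 to compound 3 (0.87 log units; beyond the scatter). The largest of these, a 7.5-fold lower number from compound 2 to compound 3 (0.87 log units; beyond the scatter), suggests that losing the 1H-benzimidazol-2-yl group could cost a modest step of similar size towards a higher number in this assay. The expected change is an 8.4-fold higher number from compound 3 to compound 4 (0.92 log units; beyond the scatter). For compound 4 the estimated value is 15000 nM, within an expected range of 6000 nM to 40000 nM.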

Compound 4, half-maximal inhibitory concentration: 21700 nM
Beside the measured number, compound 4's estimate is 1.4-fold (0.16 log units) below it, and the stated range covers the measured number.
By their numbers in this assay, from the lowest: compound 3; then compound 1; then compounds 2 and 4 (each within the scatter of the next).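

Stripping the side chain from this aromatic carbon gives a 12-fold higher number from compound 3 to compound 4 (1.08 log units; beyond the scatter) in this assay and so shows directly that the ((1H-benzimidazol-2-yl)methyl)sulfanyl group counts here. The (2,6-dichlorobenzyl)sulfanyl group also counts, with a 4.1-fold higher number from compound 1 to compound 4 (0.61 log units; beyond the scatter) as its loss. Propargylsulfanyl goes against this, since a 1.6-fold higher number from compound 2 to compound 4 (0.21 log units; within the scatter) lies within the scatter and leaves it indistinguishable from hydrogen. Nothing here explains these differences. From the compounds shown here alone, whether a chain needs its ring system remains open, and an amine or a carboxylic acid on this carbon could test that.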